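The source may hold more compounds than are shown below. What is called first, only, known or untested is meant among the compounds shown, and "the series" means these compounds.

Compound 2, `Cc1ccc2c(NCc3ccc(NC(=O)C4CCN(Cc5ccccc5)CC4)cc3)nc(N3CCC(N4CCCC4)CC3)nc2c1`, stands only at a limit in a functional assay on SV5A8 cells (Homo sapiens) for cytotoxicity; a lower number here means a stronger inhibitor, a higher number a weaker inhibitor: compound 2 gives > 8090 nM, which is a limit of the assay and not a number. Compound 1, `Cc1ccc2c(NCc3ccc(NC(=O)C4CCN(Cc5ccc(F)cc5)CC4)cc3)nc(N(C)C)nc2c1`, likewise reaches only a limit in this assay, where compound 1 gives > 4820 nM. Going by the values given here, both values shown in this assay are limits, one recorded as the limit of > 4820 nM in this assay, at which 1 of the 2 values shown sits, and the other as the limit of > 8090 nM in this assay, at which 1 of the 2 values shown sits, so no step between measured compounds can be read from them. Compound 3, `Cc1ccc2c(NCc3ccc(NC(=O)C4CCN(Cc5ccccc5)CC4)cc3)nc(N3CCCCCC3)nc2c1`, differs from compound 2 by azepan-1-yl in place of 4-(pyrrolidin-1-yl)piperidin-1-yl on an aromatic carbon. With neither measured compound giving a number in this assay, the expected step that the limit leaves unreadable from compound 2 to compound 3 lies within the scatter. Compound 3 is therefore estimated at 10000 nM, in a range from 3000 nM to 40000 nM, most likely reported again as a limit.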

Compound 3, half-maximal inhibitory concentration: > 6880 nM
Compound 3 gave a limit, no number (the forecaster's own chance of this, stated with the estimate: 70%); the middle value is on the limit's open side.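

In this assay compound 3 gives > 6880 nM, which is a limit of the assay and not a number. Going by these compounds alone, compound 2 also stands at a limit, so no step from compound 2 to compound 3 can be read. The compounds shown leave open whether azepan-1-yl and 4-(pyrrolidin-1-yl)piperidin-1-yl differ at all in this assay.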